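Arylpiperazine exchange in the spirocyclic oxindole series

This account rests on a few compounds, and the source may have more. Where it says the series, first, only, none or still open, it means among the compounds named here.

Within the data shown here, compound 1 `CCC1(CCCCN2CCN(c3cccc(Cl)c3)CC2)C(=O)Nc2ccccc21` is the only member of the group with any reading in a functional assay on the whole organism (strain NMRI) with Mus musculus as the target, with stated times of 30 min and 5 min; a higher number here means that more compound is needed for the effect, a lower number that less compound is needed; in this assay compound 1 gives > 20 mg/kg, which is a limit of the assay and not a number. Two further members, compound 2 `CCC1(CCCCN2CCN(c3cccc(Cl)c3)CC2)C(=O)Nc2cc(F)c(Cl)cc21` and compound 3 `CCC1(CCCCN2CCN(c3ccc(Cl)cc3)CC2)C(=O)Nc2cc(F)c(Cl)cc21`, carry added fluorine and chlorine on the core and differ in the aryl group on the amine nitrogen in a ring; for compound 2 the outcome in this assay is "not determined" (no result reported), and for compound 3 it is "not determined" (no result reported). Among the measured compounds shown here, no step between measured compounds can therefore be drawn, and the only numerical anchor is the limit of > 20 mg/kg in this assay, at which 1 of the 3 values shown sits.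

Compound 4 `CCC1(CCCCN2CCN(c3ccc(F)cc3)CC2)C(=O)Nc2ccccc21` is the next compound to be tested. Its change from compound 1 is 4-fluorophenyl in place of 3-chlorophenyl on an amine nitrogen in a ring. For the measured compounds named here, with no measured step to guide it, the step expected is a number no higher from compound 1 to compound 4 (the limit leaves the size open), meaning no movement beyond the scatter. For compound 4 the minimum effective dose in this assay is estimated at 20 mg/kg, within a range from 5 mg/kg to 40 mg/kg, and a limit rather than a number remains the more probable outcome.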

Compound 4, minimum effective dose: < 1 mg/kg
Compound 4: only a limit was reported (the forecaster's own chance of this, stated with the estimate: 60%); middle value at least 20-fold (1.30 log units) away from the limit.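

Among these compounds, exchanging 3-chlorophenyl for 4-fluorophenyl on an amine nitrogen in a ring gives an at least 20-fold lower number from compound 1 to compound 4 (1.30 log units; beyond the scatter) in this assay, so the aryl group at this position strongly shapes the reading, which the earlier compounds could not show. Compound 4 stands at a limit of the assay and not at a number: the limit of < 1 mg/kg in this assay, at which 1 of the 4 values shown sits. Compound 1 also stands at a limit of the assay and not at a number, which leaves the full size of the step unread: the limit of > 20 mg/kg in this assay, at which 1 of the 4 values shown sits.

Steps involving compound 2 and compound 3 cannot be read, so it stays open whether the added fluorine and chlorine on the core alter the outcome of this exchange. The step changes the halogen and its place on the phenyl together, and 3-fluorophenyl on the core of compound 1 would separate the two.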